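A Smaller Heteroaryl Amide on a Shared Core

The source may report more compounds than this note shows. Statements on the series, on what has been measured and on what is new or still open speak of the compounds shown alone.

Compound 1 `O=C(COc1ccc(/C=C2\SC(=O)NC2=O)cc1)Nc1nc2ccccc2s1` carries a 1,3-benzothiazol-2-yl group on an amide-type nitrogen attached to a carbonyl carbon. In a functional assay on HepG2 cells (Homo sapiens) for cytotoxicity, read by sulforhodamine B assay, with a stated time of 48 h (on this read-out higher numbers stand for weaker inhibition of growth and lower numbers for stronger inhibition of growth), compound 1 gives < 100000 nM, and this is a limit of the assay rather than a measured number. Compound 2 `O=C1NC(=O)/C(=C\c2ccc(OCC(=O)N3C(=O)c4ccccc4S3(=O)=O)cc2)S1` places a different group on the same side of the shared core. In this assay compound 2 gives < 100000 nM, which again is a limit. Both compounds therefore sit at the same point, (the limit of < 100000 nM in this assay, at which 2 of the 2 values shown sit), so where compound 1 stands relative to compound 2 cannot be told from these numbers. Compound 3 `O=C(COc1ccc(/C=C2\SC(=O)NC2=O)cc1)Nc1ccccn1` is not yet measured; it differs from compound 1 in one place: pyridin-2-yl in place of 1,3-benzothiazol-2-yl on an amide-type nitrogen. Among the measured compounds shown here, no step between measured compounds is available to indicate how large such a change might be, so the step that the limit leaves unreadable from compound 1 to compound 3 is expected to be small and without a clear direction beyond the usual scatter. For compound 3 in this assay the estimate is 30000 nM, with a range from 5000 nM to 100000 nM, and a limit rather than a number is expected to be quite likely.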

Compound 3, concentration for total growth inhibition: < 100000 nM
Compound 3: only a limit was reported; the forecaster's own chance of this, stated with the estimate: 60%; the middle value is on the limit's open side.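

No step can be read from compound 1 to compound 3, since the results for both in this assay are limits of the assay and not numbers: the limit of < 100000 nM in this assay, at which 3 of the 3 values shown sit.

The compounds shown leave open how strongly each one inhibits growth, and whether pyridin-2-yl in place of 1,3-benzothiazol-2-yl changes that at all.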